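The source may hold more compounds than are shown below. What is called first, only, known or untested is meant among the compounds shown, and "the series" means these compounds.

Going by the values given here, in a functional assay on HCT-116 cells (Homo sapiens) for inhibition, read by MTT assay, with a stated time of 72 h, tested at 20 uM (on this read-out higher numbers stand for more inhibition at the one concentration tested (going by the name of the read-out) and lower numbers for less inhibition), compound 2 `c1cc(N2CCCCC2)nc(Nc2ccc(Oc3ncnc4ccsc34)cc2)n1` gives 61.5%, the higher of the two numbers measured so far. Compound 1 `c1ccc2c(c1)CCN(c1ccnc(Nc3ccc(Oc4ncnc5ccsc45)cc3)n1)C2` gives 40.9% in this assay. Compound 3 `c1cc(N2CCCC2)nc(Nc2ccc(Oc3ncnc4ccsc34)cc2)n1` differs from compound 2 in one place: pyrrolidin-1-yl in place of piperidin-1-yl on an aromatic carbon. Among the compounds with values here, the only measured step that bears on this is a number 20.6 percentage points higher from compound 1 to compound 2 (beyond the scatter), where 1,2,3,4-tetrahydroisoquinolin-2-yl gave way to piperidin-1-yl. Moving from a six-membered to a five-membered non-aromatic ring is a smaller alteration, so the expected step of a number 3.5 percentage points lower from compound 2 to compound 3 (within the scatter) is small and within the scatter. Compound 3 is therefore estimated at 58%, in the range 40% to 76%.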

Compound 3, a percentage reported as inhibition, at one concentration (the size of the read-out at that concentration, not a potency): 22.2%
Beside the measured number, compound 3's estimate is 35.8 percentage points above it; measured number outside the range, below it.
By their numbers in this assay, from the lowest: compound 3; then compound 1; then compound 2.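

Pyrrolidin-1-yl in place of piperidin-1-yl gives a number 39.3 percentage points lower from compound 2 to compound 3 (beyond the scatter) in this assay, so a small change in ring size at this position can matter a great deal. In place of 1,2,3,4-tetrahydroisoquinolin-2-yl, it gives a number 18.7 percentage points lower from compound 1 to compound 3 (beyond the scatter) as well, so the numbers do not simply follow group size: compound 1, with the largest group, lies between the other two. Nothing available here explains this drop. From the compounds shown here alone, whether morpholin-4-yl or an open-chain amine such as dimethylamino would keep the number of compound 2 remains open.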